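Trifluoromethyl in place of trifluoromethoxy: what to expect

A few compounds are considered here, and "the series" means these few. Any claim that something is new, unique, unknown or untested is made for them only; others in the source may bear on it.

Compound 1 `Cc1cccc(-c2nc3cc(C)ccc3c(=O)[nH]2)c1`: 21100 nM
Compound 2 `Cc1ccc2c(=O)[nH]c(-c3cccc(F)c3)nc2c1`: 14400 nM
Compound 3 `Cc1ccc2c(=O)[nH]c(-c3cccc(OC(F)(F)F)c3)nc2c1`: > 50000 nM (a limit, not a number)

These results come from a functional assay on HCT-15 cells (Homo sapiens) for cytotoxicity, read by MTT assay, with a stated time of 2 days; a lower number here means a stronger inhibitor, a higher number a weaker inhibitor. Compound 3 has no exact number, only (the limit of > 50000 nM in this assay, at which 1 of the 3 values shown sits).

Compound 4 `Cc1ccc2c(=O)[nH]c(-c3cccc(C(F)(F)F)c3)nc2c1` has not yet been measured. It carries trifluoromethyl in place of trifluoromethoxy on an aromatic carbon of a six-membered aromatic ring of carbon only (trifluoromethyl in place of trifluoromethoxy on an aromatic carbon).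

Three measured steps at this same place bear on the change. Fluoro in place of methyl gave a 1.5-fold lower number from compound 1 to compound 2 (0.17 log units; within the scatter). Trifluoromethoxy in place of methyl gave an at least 2.3-fold higher number from compound 1 to compound 3 (0.37 log units; beyond the scatter), and trifluoromethoxy in place of fluoro gave an at least 3.4-fold higher number from compound 2 to compound 3 (0.54 log units; beyond the scatter). Among these three compounds, then, only the arrival of trifluoromethoxy moved the number beyond the scatter, and both of those steps are known only as minimum sizes.

Removing that group should therefore reverse at least part of the step of an at least 2.3-fold higher number from compound 1 to compound 3 (0.37 log units; beyond the scatter). Trifluoromethyl itself has no measurement in this set, so the expectation is loose. In this assay, the expected change is an at least 1.7-fold lower number from compound 3 to compound 4 (0.25 log units; that floor lies within the scatter), a modest step towards a lower number. Compound 4 is estimated at 28000 nM, with an expected range from 12000 nM to 50000 nM.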

Compound 4, half-maximal inhibitory concentration: > 50000 nM
Compound 4: a limit, no number; the forecaster's own chance of this, stated with the estimate: 30%; at least 1.7-fold (0.25 log units) between middle value and limit.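

In this assay compound 4 gives > 50000 nM, which is a limit of the assay and not a number. The step between compound 3 and compound 4 cannot be read, so this change of group can be given neither a direction nor a size, and the two compounds can only be said to share the same limit: the limit of > 50000 nM in this assay, at which 2 of the 4 values shown sit.

Going by these compounds alone, what is new is that trifluoromethoxy is no longer the only group at this position with a number this high: trifluoromethyl, which lacks the oxygen of trifluoromethoxy, gives an at least 3.4-fold higher number from compound 2 to compound 4 (0.54 log units; beyond the scatter) and an at least 2.3-fold higher number from compound 1 to compound 4 (0.37 log units; beyond the scatter), so taking that oxygen away does not bring the result back to the level of the methyl and fluoro compounds.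

Going by these compounds, how far compound 3 and compound 4 each lie past the limit stays open, and so does any true difference between them. Also open, on these data alone, is whether a different kind of group at this position, such as an amine or a carboxylic acid, would give a lower number than the methyl and fluoro compounds or a reading past the limit.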